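The source may report more compounds than this note shows. Statements on the series, on what has been measured and on what is new or still open speak of the compounds shown alone.

In a functional assay on MDA-MB-231 cells (Homo sapiens) for antiproliferative activity, with a stated time of 4 days (on this read-out higher numbers stand for weaker inhibition and lower numbers for stronger inhibition), compound 1 `CCCCc1ccc2[nH]c(-c3ccc(OC)cc3)c(/C=N/NC(=O)c3ccc(Cl)cc3)c2c1` gives 90 nM and compound 3 `CCCCc1ccc2[nH]c(-c3ccc(CC)cc3)c(/C=N/NC(=O)c3ccncc3)c2c1` gives 80 nM. Compound 2 `CCCCc1ccc2[nH]c(-c3ccc(C(F)(F)F)cc3)c(/C=N/NC(=O)c3ccc(Cl)cc3)c2c1` gives 329 nM, the highest of the three numbers and so the weakest inhibition. Compound 4 `CCCCc1ccc2[nH]c(-c3ccc(C(F)(F)F)cc3)c(/C=N/NC(=O)c3ccccn3)c2c1` differs from compound 2 on the carbonyl carbon: pyridin-2-yl in place of 4-chlorophenyl on a carbonyl carbon. Going by the values given here, the one measured step, a 3.7-fold higher number from compound 1 to compound 2 (0.56 log units; beyond the scatter), is a trifluoromethyl in place of methoxy, a change made elsewhere, so it does not bear directly on this replacement. Compound 3, at 80 nM, also has a ring with a hetero atom on its carbonyl carbon, but it differs from compound 2 in more than one place, so it offers only a weak hint of a lower number. The expected step, a 1.3-fold lower number from compound 2 to compound 4 (0.12 log units; within the scatter), is therefore small and slightly downward, within the scatter. For compound 4 the estimated value is 250 nM, with an expected range of 90 nM to 700 nM.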

Compound 4, half-maximal inhibitory concentration: 260 nM
Beside the measured number, compound 4's estimate is 1.0-fold (0.02 log units) below it; measured number inside the range.
By their numbers in this assay, from the lowest: compounds 3 and 1 (each within the scatter of the next); then compounds 4 and 2 (each within the scatter of the next).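

Replacing 4-chlorophenyl with pyridin-2-yl on the carbonyl carbon gives a 1.3-fold lower number from compound 2 to compound 4 (0.10 log units; within the scatter) in this assay and leaves compounds 2 and 4 indistinguishable. Going by these compounds alone, this is the first one-place comparison at this position, and it shows that, with trifluoromethyl on the aryl ring, a ring with one hetero atom can stand here in place of the chlorinated carbon ring without a readable shift. Nothing given here explains this result. As far as these compounds go, whether the same replacement would read alike with the methoxy of compound 1 remains open. So does the effect of an aliphatic amine or a carboxylic acid on this carbonyl carbon.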